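The source may report more compounds than this note shows. Statements on the series, on what has been measured and on what is new or still open speak of the compounds shown alone.

In a functional assay on HT-29 cells (Homo sapiens) for inhibition, read by sulforhodamine B assay, with a stated time of 48 h (on this read-out higher numbers stand for weaker inhibition of growth and lower numbers for stronger inhibition of growth), compound 1 `COc1cc(C(=O)NNC(=O)c2ccc3[nH]c(-c4ccc([N+](=O)[O-])s4)nc3c2)cc(OC)c1OC` gives 62.5 ug/mL and compound 2 `O=CNNC(=O)c1ccc2[nH]c(-c3ccc([N+](=O)[O-])o3)nc2c1` gives 62.5 ug/mL. Compound 3 `COc1ccc(C(=O)NNC(=O)c2ccc3[nH]c(-c4ccc([N+](=O)[O-])o4)nc3c2)cc1OC` gives 15.6 ug/mL, the lowest of the three numbers and beyond the scatter from both others. Compound 4 `COc1cc(C(=O)NNC(=O)c2ccc3[nH]c(-c4ccc([N+](=O)[O-])o4)nc3c2)cc(OC)c1OC`, still unmeasured, carries methoxy in place of hydrogen on an aromatic carbon of compound 3: methoxy in place of hydrogen on an aromatic carbon. For the measured compounds named here, the only measured step, a 4.0-fold lower number from compound 2 to compound 3 (0.60 log units; beyond the scatter), puts 3,4-dimethoxyphenyl in place of hydrogen on a carbonyl carbon. That is a different change, so it offers only weak guidance here. No step beyond the scatter is expected in this assay, and no firm direction can be given. The expected step is a 1.3-fold higher number from compound 3 to compound 4 (0.11 log units; within the scatter). For compound 4 the estimated value is 20 ug/mL, with an expected range from 7.8 ug/mL to 62.5 ug/mL.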

Compound 4, concentration for 50% growth inhibition: 31.3 ug/mL
Estimate against measurement, compound 4: 1.6-fold (0.19 log units) below; measured number inside the range.
By their numbers in this assay, from the lowest: compounds 3, 4, 1 and 2 (each within the scatter of the next, the first and the last beyond it).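

In this assay, the added methoxy, ortho to a methoxy group, gives a 2.0-fold higher number from compound 3 to compound 4 (0.30 log units; within the scatter), so this position accepts a further methoxy with no shift that stands clear of the usual variation. With everything else kept, placing 5-nitrofuran-2-yl where 5-nitrothiophen-2-yl stood gives a 2.0-fold lower number from compound 1 to compound 4 (0.30 log units; within the scatter), so this exchange cannot be told apart from the scatter either. No supporting data are available to explain either result. Still open, as far as these compounds go, is how an amine or a hydroxy group would behave at this position. Also open, from the compounds shown here alone, is whether the furan and thiophene exchange would read the same with a different group on the carbonyl.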